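This account rests on a few compounds, and the source may have more. Where it says the series, first, only, none or still open, it means among the compounds named here.

The study compares urea derivatives built on one shared core, and in an ADME assay on BJ cells (Homo sapiens) for cytotoxicity, with a stated time of 72 h (a lower number here means that less compound is needed, a higher number that more compound is needed for the effect), the measurements are spread thinly. Compound 1 `Cc1cc(NC(=O)Nc2cccc([N+](=O)[O-])c2)c2ccccc2n1` reaches only the limit of the measurement: in this assay compound 1 gives > 25000 nM, which is a limit and not a number, as shown by the limit of > 25000 nM in this assay, at which 1 of the 2 values shown sits. For the measured compounds named here, compound 2 `Cc1cc(NC(=O)Nc2cc(F)ccc2F)c2ccccc2n1` is the only compound with a numeric value, and in this assay compound 2 gives 7000 nM. Going by the values given here, no pair of compounds here differs in a single place, so no measured step is available to guide the next comparison. Compound 3 `Cc1cc(NC(=O)Nc2cccc(C(C)(C)C)c2)c2ccccc2n1` differs from compound 1 by tert-butyl in place of nitro on an aromatic carbon. Since compound 1 sits at the limit, any step can only be read in one direction. For compound 3 a moderate move toward a lower number than the limit of compound 1 is expected, with an estimated step of an at least 1.7-fold lower number from compound 1 to compound 3 (0.25 log units; that floor lies within the scatter). Compound 3 is therefore estimated at 14000 nM, within a range from 5000 nM to 30000 nM.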

Compound 3, half-maximal effective concentration: > 25000 nM
Compound 3 ended at the assay's limit; the forecaster's own chance of this, stated with the estimate: 35%; at least 1.7-fold (0.25 log units) between middle value and limit.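

Compound 1 and compound 3 both sit at the limit of this assay, so no step can be read between them, and tert-butyl in place of nitro leaves no measurable size: the limit of > 25000 nM in this assay, at which 2 of the 3 values shown sit.

What the compounds shown leave open is how far either compound lies past that limit.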